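This account rests on a few compounds, and the source may have more. Where it says the series, first, only, none or still open, it means among the compounds named here.

Compound 1, `O=S(=O)(NCCNCc1ccc(-c2ccccc2)cc1)c1cc(C(F)(F)F)cc(C(F)(F)F)c1`, gives 4200 nM.
Compound 2, `O=S(=O)(NCCCNCc1ccc(C(F)(F)F)cc1)c1cc(C(F)(F)F)cc(C(F)(F)F)c1`, gives 3200 nM.
Compound 3, `O=S(=O)(NCCCNCc1ccc(-c2ccccc2)cc1)c1cc(C(F)(F)F)cc(C(F)(F)F)c1`, gives 2500 nM.

All three numbers come from a functional assay on PANC-1 cells (Homo sapiens) for inhibition, read by MTT assay, with a stated time of 72 h; a higher number here means a weaker inhibitor of growth, a lower number a stronger inhibitor of growth. Compound 2 stands second highest of the three, with compound 3 nearest at a 1.3-fold lower number from compound 2 to compound 3 (0.11 log units; within the scatter) and compound 1 furthest, both within the scatter, so the three compounds cannot be told apart on these numbers.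

The next compound, compound 4, `COc1ccccc1CNCCCNS(=O)(=O)c1cc(C(F)(F)F)cc(C(F)(F)F)c1`, is not yet measured. It differs from compound 2 in one place: 2-methoxyphenyl in place of 4-(trifluoromethyl)phenyl on a saturated chain carbon bound to an amine nitrogen. Among the compounds with values here, the only measured step that touches this part of the molecule is the one from compound 2 to compound 3, where phenyl replaced trifluoromethyl on an aromatic carbon and the number moved a 1.3-fold lower number from compound 2 to compound 3 (0.11 log units; within the scatter), within the scatter. Within the data shown here, no measured step shows a methoxy group or a change of position on that ring, so nothing here points to a large move in either direction. The expectation for compound 4 is therefore a step of about a 1.1-fold higher number from compound 2 to compound 4 (0.04 log units; within the scatter) in this assay, no further than the scatter from compound 2. Compound 4 is estimated at 3500 nM, with a range from 1500 nM to 8000 nM.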

Compound 4, concentration for 50% growth inhibition: 12000 nM
For compound 4 the middle estimate is 3.4-fold (0.54 log units) below the measured one, and the stated range ends below it.
By their numbers in this assay, from the lowest: compounds 3, 2 and 1 (each within the scatter of the next); then compound 4.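

In this assay, within the data shown here, putting 2-methoxyphenyl in place of 4-(trifluoromethyl)phenyl on the saturated chain carbon bound to an amine nitrogen gives a 3.8-fold higher number from compound 2 to compound 4 (0.57 log units; beyond the scatter), the first single change in this set to go beyond the scatter, and it goes towards weaker growth inhibition. The ring on this side of the molecule therefore does not accept every replacement equally: swapping its trifluoromethyl for phenyl gave only a 1.3-fold lower number from compound 2 to compound 3 (0.11 log units; within the scatter), whereas this swap changes both the group on the ring and its position on the ring, and the step cannot be divided between those two changes. No measurement here explains why the number rose.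

The compounds shown leave open whether the loss follows the methoxy group or its position, a question that 4-methoxyphenyl and 2-(trifluoromethyl)phenyl in the same place would help to separate. They also leave open how a ring carrying a carboxylic acid or an amine would behave here, and whether the same loss would appear with a longer chain in the core.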